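A few compounds are considered here, and "the series" means these few. Any claim that something is new, unique, unknown or untested is made for them only; others in the source may bear on it.

Cytotoxicity series on the shared core.

Compound 1 `CCCCCc1ccc(-c2cc3cn([C@H]4C[C@H](O)[C@@H](CO)O4)c(=O)nc3o2)cn1` is one of three measured members. In an ADME assay on HEL cells (Homo sapiens) for cytotoxicity, with a stated time of 3 days (a higher number here means that more compound is tolerated, a lower number that less compound is tolerated), compound 1 gives 100000 nM. Compound 2 `CCCCCc1cnc(-c2cc3cn([C@H]4C[C@H](O)[C@@H](CO)O4)c(=O)nc3o2)nc1` carries a pentyl chain on a different six-membered aromatic ring. In this assay compound 2 reaches only a limit of the measurement, > 100000 nM, and no number. Compound 3 `CCCCCCc1ccc(-c2cc3cn([C@H]4C[C@H](O)[C@@H](CO)O4)c(=O)nc3o2)nc1` bears a hexyl chain on the same kind of ring as compound 1. In this assay compound 3 likewise sits at a limit, > 100000 nM. So compound 2 stands where the measurements stop, at the limit of > 100000 nM in this assay, at which 2 of the 3 values shown sit, together with compound 3, while compound 1 gives a number at the same concentration.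

Compound 4 `CCCCCCc1cnc(-c2cc3cn([C@H]4C[C@H](O)[C@@H](CO)O4)c(=O)nc3o2)nc1` is not yet measured. It differs from compound 2 by methyl in place of hydrogen on a saturated chain carbon, five bonds along the chain from an aromatic carbon. Within the data shown here, no measured pair carries this change by itself, so no step size is known; given the position of compound 2 at > 100000 nM, the expectation is for no shift beyond the scatter in this assay, with the value of compound 4 most likely remaining at a limit. The estimate for compound 4 is 100000 nM, between 50000 nM and 200000 nM, which is an expected step from compound 2 to compound 4 of a number no higher from compound 2 to compound 4 (the limit leaves the size open).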

Compound 4, minimum cytotoxic concentration: > 100000 nM
Compound 4 was reported as a limit; the forecaster's own chance of this, stated with the estimate: 70%; the middle value sits exactly at the limit.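

In this assay compound 2 and compound 4 both sit at a limit of the measurement, so no step between them can be read: the limit of > 100000 nM in this assay, at which 3 of the 4 values shown sit.

The compounds shown leave open how far either value lies past that limit, and whether methyl in place of hydrogen on the chain changes it.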